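The source may report more compounds than this note shows. Statements on the series, on what has been measured and on what is new or still open speak of the compounds shown alone.

Values measured in a functional assay on DU-145 cells (Homo sapiens) for cytotoxicity, read by MTT assay, with a stated time of 48 h (on this read-out lower numbers stand for stronger inhibition and higher numbers for weaker inhibition), are as follows

Compound 1 `COc1cc(/C=C/c2ccccc2)c(-c2ccccc2)c(OC)c1OC` gives 82000 nM
Compound 2 `COc1cc(/C=C/c2ccc(C)cc2)c(-c2ccccc2)c(OC)c1OC` gives 101000 nM
Compound 3 `C=C(c1ccccc1)c1cc(OC)c(OC)c(OC)c1-c1ccccc1` gives 36000 nM

Of these three, compound 3 has the lowest number, and its steps to both of the others lie beyond the scatter. Compound 4 `C=C(c1ccc(Cl)cc1)c1cc(OC)c(OC)c(OC)c1-c1ccccc1` differs from compound 3 in one place, with chloro in place of hydrogen on an aromatic carbon, para to a large group: chloro in place of hydrogen on an aromatic carbon is the whole change.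

The closest measured comparison also replaces hydrogen on an aromatic carbon with a single group, in that case methyl. In this assay that replacement gave a 1.2-fold higher number from compound 1 to compound 2 (0.09 log units; within the scatter) and so no real change. It is only a guide, since methyl is not chloro and that pair carries 2-phenylethenyl rather than 1-phenylethenyl. The steps of a 2.3-fold lower number from compound 1 to compound 3 (0.36 log units; beyond the scatter) and a 2.8-fold lower number from compound 2 to compound 3 (0.45 log units; beyond the scatter) are modest. They swap the whole ethenyl group rather than add a substituent, so they show only how far numbers move in this small set. Going by the values given here, no chlorinated compound has been measured yet.

No step beyond the scatter is therefore expected, and the estimated step is a 1.1-fold lower number from compound 3 to compound 4 (0.05 log units; within the scatter) as the best guess. Compound 4 is expected to give about 32000 nM with an estimated range from 13000 nM to 75000 nM on this reasoning.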

Compound 4, half-maximal inhibitory concentration: 29000 nM
Beside the measured number, compound 4's estimate is 1.1-fold (0.04 log units) above it; the measured number falls inside the stated range.
By their numbers in this assay, from the lowest: compounds 4 and 3 (each within the scatter of the next); then compounds 1 and 2 (each within the scatter of the next).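

Chloro is the first halogen in this set, and at this position, on the aromatic carbon para to a large group, it makes no real difference in this assay: the result is a 1.2-fold lower number from compound 3 to compound 4 (0.09 log units; within the scatter), so this site accepts a chlorine atom without a measurable loss or gain. The advantage of the 1-phenylethenyl arrangement also survives the change, since the chlorinated compound keeps a modest edge over both compounds with a 2-arylethenyl group, with a 2.8-fold lower number from compound 1 to compound 4 (0.45 log units; beyond the scatter) and a 3.5-fold lower number from compound 2 to compound 4 (0.54 log units; beyond the scatter), and none of the four compounds goes against this split. Nothing measured here explains why the number holds still when chloro enters.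

Going by these compounds, whether a very different group at this same position, such as an amine or a carboxylic acid, would move the number remains open, as does whether chloro would act the same way on the 2-phenylethenyl compounds. On these data alone, the phenyl group on the shared core and the three methoxy groups are the same in all four compounds, so what they contribute also remains unknown.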